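A few compounds are considered here, and "the series" means these few. Any claim that something is new, unique, unknown or untested is made for them only; others in the source may bear on it.

Working notes on the series: compound 1 `CC(C)(/C=N/OCC(=O)O)Cc1c(SC(C)(C)C)c2cc(OCc3cccc(Cl)n3)ccc2n1Cc1ccc(Cl)cc1` and compound 2 `CC(C)(/C=N/OCC(=O)O)Cc1c(SC(C)(C)C)c2cc(OCc3cscn3)ccc2n1Cc1ccc(Cl)cc1` share a core and differ in the aromatic ring on the saturated chain carbon bound to an oxygen. For the measured compounds named here, in a functional assay on the whole organism (Peritoneal cavity) with Rattus norvegicus as the target (a higher number here means that more compound is needed for the effect, a lower number that less compound is needed), compound 1 gives 2.6 umol/kg and compound 2 gives 4.4 umol/kg, so compound 2 stands level with its only measured neighbour. The exchange is a 1.7-fold higher number from compound 1 to compound 2 (0.23 log units; within the scatter).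

Next is compound 3 `CC(C)c1ccc2c(c1)c(SC(C)(C)C)c(CC(C)(C)/C=N/OCC(=O)O)n2Cc1ccc(Cl)cc1`, with the change isopropyl in place of (1,3-thiazol-4-yl)methoxy on an aromatic carbon. Going by the values given here, only that one measured step bears on this change, and only partly. It swaps one ring for another and keeps the oxygen-bearing chain, whereas compound 3 loses the whole group. Among the compounds with values here, no measured pair shows what such a loss does in this assay.

Within the data shown here, with so little evidence, no step clearly beyond the scatter is expected, only a lean toward a higher number. The expected step is a 1.8-fold higher number from compound 2 to compound 3 (0.26 log units; within the scatter). The estimate for compound 3 is 8 umol/kg, with an expected range from 2.5 umol/kg to 25 umol/kg.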

Compound 3, dose for half-maximal effect: 3 umol/kg
The estimate for compound 3 lay 2.7-fold (0.43 log units) above the measured number, and the stated range covers the measured number.
By their numbers in this assay, from the lowest: compounds 1, 3 and 2 (each within the scatter of the next).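

Working notes, continued: on this aromatic carbon of a six-membered aromatic ring of carbon only, the whole (1,3-thiazol-4-yl)methoxy group gives way to isopropyl, a group with no ring and 0 hydrogen-bond acceptors, and this assay shows a 1.5-fold lower number from compound 2 to compound 3 (0.17 log units; within the scatter) for that exchange. The exchange of (6-chloropyridin-2-yl)methoxy for isopropyl reads the same way, with a 1.2-fold higher number from compound 1 to compound 3 (0.06 log units; within the scatter) and again no step beyond the scatter, so the finding extends past the ring swap of the earlier pair: across compounds 1, 2 and 3, neither the aromatic ring nor the oxygen-bearing chain at this position is tied to a step beyond the scatter. Nothing available on these compounds explains this result.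

Still open, as far as these compounds go, is whether an amine, a carboxylic acid or a longer chain on this aromatic carbon would give a step beyond the scatter in this assay at all. The three compounds also share every other part of the core, which leaves open how much those parts contribute to the numbers seen here.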